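The source may hold more compounds than are shown below. What is called first, only, known or untested is meant among the compounds shown, and "the series" means these compounds.

Measured compounds in a functional assay on A549 cells (Homo sapiens) for antiproliferative activity, read by MTT assay, with a stated time of 72 h; on this read-out higher numbers stand for weaker inhibition and lower numbers for stronger inhibition:
compound 1 `COc1ccc(OCCCON2C(N)=NC(N)=NC23CCOCC3)cc1`: 660 nM
compound 2 `CC(C)(C)c1ccc(OCCCON2C(N)=NC(N)=NC23CCSCC3)cc1`: 1 nM
compound 3 `COc1ccc(OCCCON2C(N)=NC(N)=NC23CCSCC3)cc1`: 240 nM

Compound 3 stands second highest of the three numbers; compound 1 gives 660 nM above it, compound 2 gives 1 nM well below it. Within the data shown here, the only single-place step measured, a 240-fold higher number from compound 2 to compound 3 (2.38 log units; beyond the scatter), concerns the group on the aromatic ring at the end of the chain and is large.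

Compound 4 `NC1=NC2(CCSCC2)N(OCCCOc2ccc(Cl)c(Cl)c2)C(N)=N1` differs from compound 3 by 3,4-dichlorophenyl in place of 4-methoxyphenyl on an oxygen on a saturated carbon. Among the measured compounds shown here, no measured pair covers a 3,4-dichlorophenyl, so the size of the step is uncertain; the one step that bears on it, a 240-fold higher number from compound 2 to compound 3 (2.38 log units; beyond the scatter), shows this position moving the number far in either direction. A lower number than compound 3 is expected, but not one as low as compound 2, giving an estimated step of a 6.0-fold lower number from compound 3 to compound 4 (0.78 log units; beyond the scatter) in this assay. The expected value for compound 4 is 40 nM, with a range from 5 nM to 300 nM.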

Compound 4, half-maximal inhibitory concentration: 1 nM
Compound 4: middle estimate off by 40-fold (1.60 log units), on the high side; the measured number lies below the stated range.
By their numbers in this assay, from the lowest: compounds 2 and 4 (each within the scatter of the next); then compound 3; then compound 1.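

In this assay, 3,4-dichlorophenyl in place of 4-methoxyphenyl gives a 240-fold lower number from compound 3 to compound 4 (2.38 log units; beyond the scatter) in one step, so a shift of this size at this position is not confined to the tert-butyl change. Compound 2 and compound 4 lie within the scatter of each other, although their rings carry different groups. No supporting data bear on why either change acts as it does.

Open, as far as these compounds go, is whether a single chlorine, a morpholine or a carboxylic acid on the ring holds the number, and whether a longer chain does.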